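Trifluoromethyl in Place of Chloro on the Dichlorophenyl Arm

This account rests on a few compounds, and the source may have more. Where it says the series, first, only, none or still open, it means among the compounds named here.

For the measured compounds named here, compound 3 `CC/C(=C(/c1ccc(/C=C/C(=O)O)cc1)c1cc2ccccc2[nH]1)c1ccc(Cl)cc1Cl` gives 11 nM in a functional assay on MCF7 cells (Homo sapiens) for inhibition (a higher number here means a weaker inhibitor, a lower number a stronger inhibitor), the lowest of the three numbers measured so far. Compound 1 `CC/C(=C(/c1ccc(/C=C/C(=O)O)cc1)c1cc2ccccc2[nH]1)c1cccc(C(F)(F)F)c1` gives 325 nM and compound 2 `CC/C(=C(/c1ccc(/C=C/C(=O)O)cc1)c1cc2ccccc2[nH]1)c1ccc(Cl)cc1` gives 343 nM; the step of a 1.1-fold higher number from compound 1 to compound 2 (0.02 log units; within the scatter) is within the scatter, whereas a 30-fold lower number from compound 1 to compound 3 (1.47 log units; beyond the scatter) and a 31-fold lower number from compound 2 to compound 3 (1.49 log units; beyond the scatter) are large. Compound 4 `CC/C(=C(/c1ccc(/C=C/C(=O)O)cc1)c1cc2ccccc2[nH]1)c1ccc(Cl)cc1C(F)(F)F` differs from compound 3 by trifluoromethyl in place of chloro on an aromatic carbon. Going by the values given here, the one step that touches that aromatic carbon is a 31-fold lower number from compound 2 to compound 3 (1.49 log units; beyond the scatter), which added the chloro, and a 1.1-fold higher number from compound 1 to compound 2 (0.02 log units; within the scatter) shows trifluoromethyl and chloro on other carbons giving numbers within the scatter of each other. Among the compounds with values here, no measured step exchanges the two groups at this carbon. For compound 4 a step of a 1.8-fold higher number from compound 3 to compound 4 (0.26 log units; within the scatter) is expected, probably within the scatter. Compound 4 is estimated at 20 nM, between 6 nM and 70 nM.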

Compound 4, half-maximal inhibitory concentration: 4 nM
Beside the measured number, compound 4's estimate is 5.0-fold (0.70 log units) above it; measured number below the stated range.
By their numbers in this assay, from the lowest: compound 4; then compound 3; then compounds 1 and 2 (each within the scatter of the next).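

At this aromatic carbon, ortho to a large group, the two groups are not interchangeable in this assay: the exchange gives a 2.8-fold lower number from compound 3 to compound 4 (0.44 log units; beyond the scatter), modest but beyond the scatter. Trifluoromethyl in place of hydrogen gives an 86-fold lower number from compound 2 to compound 4 (1.93 log units; beyond the scatter), and the full change of aryl arm gives an 81-fold lower number from compound 1 to compound 4 (1.91 log units; beyond the scatter), so compound 4 has the lowest number of the four. No evidence shown explains this gain. As far as these compounds go, whether an amine, a methoxy group or a longer chain at this carbon would keep such a number remains open.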